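The compounds below may be only part of what the source reports. "The series", "measured", "known", "first", "only" and "open" are said of these compounds alone.

Working notes on the chain series in a toxicity assay on Vero cells (Chlorocebus sabaeus); on this read-out lower numbers stand for stronger inhibition and higher numbers for weaker inhibition. Compound 1 `CCCCCCCC(=O)c1cc(O)c(O)c(O)c1` gives > 299000 nM, which is a limit and not a number. Compound 2 `CCCCCCCCCCCCC(=O)c1cc(O)c(O)c(O)c1` gives > 299000 nM, which is also a limit and not a number. Compound 2 therefore has no exact position on the scale, and the record so far is the limit of > 299000 nM in this assay, at which 2 of the 2 values shown sit.

The next structure is compound 3 `CCCCCCCCCCCCCCC(=O)c1cc(O)c(O)c(O)c1`. The change is ethyl in place of hydrogen on a saturated chain carbon, ten or more bonds along the chain from a carbonyl carbon. Going by the values given here, the only measured step bearing on it, a step that the two limits leave unreadable from compound 1 to compound 2, gives no readable size, so no step beyond the scatter is expected in this assay. The expected step is a step that the limit leaves unreadable from compound 2 to compound 3. Compound 3 is estimated at 300000 nM, with an expected range of 120000 nM to 600000 nM.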

Compound 3, half-maximal inhibitory concentration: > 299000 nM
Compound 3: only a limit was reported; the forecaster's own chance of this, stated with the estimate: 75%; the middle value lies beyond the limit too.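

Compound 3 adds no readable step, and its steps from compound 1 and compound 2 cannot be read, as all of these results are limits and not numbers: the limit of > 299000 nM in this assay, at which 3 of the 3 values shown sit. The compounds shown leave open whether any chain length gives a number rather than a limit in this assay at all.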